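Swapping the Aryl Arm on the Acid Version

This account rests on a few compounds, and the source may have more. Where it says the series, first, only, none or still open, it means among the compounds named here.

Compound 1 `CCOC(=O)c1cc(-c2cc(OC)c(OC)c(OC)c2)c(-c2ccc(OC)cc2)s1` carries an ethyl ester, and in a functional assay on HT-1080 cells (Homo sapiens) for antiproliferative activity, read by MTT assay, with a stated time of 72 h (on this read-out higher numbers stand for weaker inhibition and lower numbers for stronger inhibition), compound 1 gives 8370 nM. Compound 2 `CCOC(=O)c1cc(-c2cc(OC)c(OC)c(OC)c2)c(-c2cccc(Br)c2)s1` differs from it by 3-bromophenyl in place of 4-methoxyphenyl on an aromatic carbon. In this assay compound 2 reaches only a limit of the assay, > 100000 nM. That change thus made an at least 11-fold higher number from compound 1 to compound 2 (1.07 log units; beyond the scatter), one value sitting at the limit of > 100000 nM in this assay, at which 1 of the 3 values shown sits. Compound 3 `COc1ccc(-c2sc(C(=O)O)cc2-c2cc(OC)c(OC)c(OC)c2)cc1` differs from compound 1 by hydrogen in place of ethyl on an oxygen next to a carbonyl group, a step of a 1.2-fold lower number from compound 1 to compound 3 (0.09 log units; within the scatter), and in this assay compound 3 gives 6770 nM. Compound 4 `COc1cc(-c2cc(C(=O)O)sc2-c2cccc(Br)c2)cc(OC)c1OC` has not been measured and differs from compound 3 by 3-bromophenyl in place of 4-methoxyphenyl on an aromatic carbon. Within the data shown here, this is the same kind of change as the one from compound 1 to compound 2, though the place is now two ring bonds from the ring atom that bears a carboxy group (3 heavy atoms) rather than an ethoxycarbonyl group (5 heavy atoms). Because the same change produced an at least 11-fold higher number from compound 1 to compound 2 (1.07 log units; beyond the scatter), compound 4 is expected to give 80000 nM, quite possibly only as a limit again. The expected step is a 12-fold higher number from compound 3 to compound 4 (1.07 log units; beyond the scatter), and the estimated range runs from 30000 nM to 250000 nM.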

Compound 4, half-maximal inhibitory concentration: > 100000 nM
Compound 4: only a limit was reported; the forecaster's own chance of this, stated with the estimate: 55%; at least 1.2-fold (0.09 log units) between middle value and limit.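

On the acid core as well, 3-bromophenyl in place of 4-methoxyphenyl sharply weakens the result in this assay, giving an at least 14-fold higher number from compound 3 to compound 4 (1.16 log units; beyond the scatter). So the change carries over from the ester core to the acid core in direction and as a large step, but this does not show that it has the same size on both cores: the same change on two cores in this assay, an at least 11-fold higher number (1.07 log units; beyond the scatter) from compound 1 to compound 2 and an at least 14-fold higher number (1.16 log units; beyond the scatter) from compound 3 to compound 4; the limit leaves it open whether they differ Compound 2 and compound 4 both stop at a limit rather than a number, so the step between them cannot be read, and it stays unknown whether swapping ethyl ester for acid matters when the 3-bromophenyl arm is present: the limit of > 100000 nM in this assay, at which 2 of the 4 values shown sit.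

The compounds shown leave open whether the loss comes from losing the methoxy group, from bringing in bromine, or from where the group sits on the phenyl ring; a 4-bromophenyl or a 3-methoxyphenyl arm would help to pull these apart. They also leave open whether the same change would behave alike on a core carrying an amide in place of the carboxylic acid.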